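Swapping a Nitrile for Trifluoromethyl on the Benzyl Ring

The source may report more compounds than this note shows. Statements on the series, on what has been measured and on what is new or still open speak of the compounds shown alone.

Measured so far:
- compound 1, `CCC[C@H](C(N)=O)N(Cc1ccc(OC)c(F)c1)S(=O)(=O)c1ccc(Cl)cc1`, gives 72% in a functional assay on the whole organism (brain) with Mus musculus as the target, with a stated time of 180 min, at a dose of 200 umol/kg by the oral route; a lower number here means less inhibition, a higher number more inhibition at the dose given (going by the name of the read-out)
- compound 2, `N#Cc1ccc(CN([C@H](CC2CC2)C(N)=O)S(=O)(=O)c2ccc(Cl)cc2)cc1`, gives 75% in this assay

Among the measured compounds shown here, only two compounds have numbers here, and they sit close together. Compound 2 has the larger of the two readings, but compound 1 lies only a few points away, well within the usual scatter of repeated measurements, so the two cannot be told apart and neither number may be called the higher one. For the measured compounds named here, both share the same sulfonamide-amide core and differ in the benzyl substituent and the side chain, and no single-change step between them is available.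

Compound 3, `NC(=O)[C@@H](CC1CC1)N(Cc1ccc(C(F)(F)F)cc1)S(=O)(=O)c1ccc(Cl)cc1`, is the next member. It keeps everything of compound 2 except one group: trifluoromethyl in place of cyano on an aromatic carbon. Going by the values given here, no measured pair shows what this change does, so there is no step to lean on. With compound 2 at 75% and compound 1 close by, the expected step of a number 5 percentage points lower from compound 2 to compound 3 (within the scatter) is small, most likely within the scatter, with a slight lean downward. Compound 3 is therefore estimated at 70%, with a range from 50% to 88%.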

Compound 3, a percentage reported as inhibition, in the whole organism at one dose (the size of the read-out at that dose, not a potency): 78%
For compound 3 the middle estimate is 8 percentage points below the measured one; the range from low to high includes it.
By their numbers in this assay, from the lowest: compounds 1, 2 and 3 (each within the scatter of the next).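

Among the compounds shown here, this pair is the first that differs in one place only, so it gives a direct reading of one change: trifluoromethyl in place of cyano on the six-membered aromatic ring, para to a large group, gives a number 3 percentage points higher from compound 2 to compound 3 (within the scatter) in this assay. At this place the two groups cannot be told apart in this read-out, even though the triple bond and the hydrogen-bond acceptor of the cyano group leave and a larger group with no such acceptor enters. For the compounds shown here, no measurement of any property of the two groups accompanies this result, so the pair shows only that the reading holds, and offers no explanation for it.

Whether this place accepts any group at all remains open, since a carboxylic acid, an amine or a plain hydrogen on the same carbon could behave quite differently from the two groups shown here. Also open, on these data alone, is what a longer chain would do in place of the side chain shared by compound 2 and compound 3, and whether these two compounds would still match at doses other than the single one used here.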